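The source may report more compounds than this note shows. Statements on the series, on what has been measured and on what is new or still open speak of the compounds shown alone.

Measured compounds:
compound 1 `COc1cc(C(=O)N/N=C/c2ccc(F)c(F)c2)cc(OC)c1OC` gives 33.1% in a functional assay on BGC-823 cells (Homo sapiens) for antiproliferative activity, read by MTT assay, tested at 1 uM; on this read-out higher numbers stand for a stronger effect at the one concentration tested and lower numbers for a weaker effect;
compound 2 `COc1cc(C2=NN(C(C)=O)C(c3cc(Cl)cc(Cl)c3)O2)cc(OC)c1OC` gives 0% in this assay;
compound 3 `COc1cc(C(=O)N/N=C/c2ccccc2C(F)(F)F)cc(OC)c1OC` gives 22.1% in this assay.

Compound 2 stands lowest of the three numbers. Its nearest neighbour is compound 3, whose number lies higher by a gap beyond the usual scatter, and compound 1 lies further above it, again beyond the scatter. Compound 4 `COc1ccc(OC)c(C2OC(c3cc(OC)c(OC)c(OC)c3)=NN2C(C)=O)c1` has not yet been measured. It differs from compound 2 in one place: 2,5-dimethoxyphenyl in place of 3,5-dichlorophenyl on a saturated ring carbon. Among the compounds with values here, no step between measured compounds shows what this exchange on the saturated ring carbon does, so the expectation rests only on where compound 2 stands. Since compound 2 sits at the bottom of the scale, the step from compound 2 to compound 4 is expected to be small and, if anything, upward, of the size a number 10 percentage points higher from compound 2 to compound 4 (within the scatter). For compound 4 the estimated value in this assay is 10%, with a range from 0% to 35%.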

Compound 4, a percentage reported as inhibition, at one concentration (the size of the read-out at that concentration, not a potency): 0.4%
The estimate for compound 4 lay 9.6 percentage points above the measured number; measured number inside the range.
By their numbers in this assay, from the lowest: compounds 2 and 4 (each within the scatter of the next); then compound 3; then compound 1.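

In this assay, within the data shown here, placing 2,5-dimethoxyphenyl instead of 3,5-dichlorophenyl on the saturated ring carbon gives a number 0.4 percentage points higher from compound 2 to compound 4 (within the scatter) and is the first exchange that can be read at this position. The read-out therefore does not separate these two substituted phenyl groups: compound 2 gives 0% and compound 4 gives 0.4% at the one concentration tested, so replacing the two chlorines with two methoxy groups at different ring positions leaves the effect low. Nothing available explains this result.

The compounds shown leave open whether a phenyl ring carrying an amine or a carboxylic acid on this saturated ring carbon would raise the read-out. They also leave open what would happen if a longer acyl chain such as butanoyl took the place of the acetyl group.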